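Swapping Bromo for Methyl on an Antiproliferative Compound

This account rests on a few compounds, and the source may have more. Where it says the series, first, only, none or still open, it means among the compounds named here.

In a functional assay on NCI-H460 cells (Homo sapiens) for antiproliferative activity, read by MTT assay, with a stated time of 48 h (a higher number here means a weaker inhibitor, a lower number a stronger inhibitor), compound 1 `COc1cc(-c2cccc3nc(-c4ccccc4)oc23)cc(OC)c1OC` gives 6800 nM. Compound 2 `COc1cc(-c2cccc3nc(-c4ccc(Br)cc4)oc23)cc(OC)c1OC` gives > 25000 nM, which is a limit and not a number. This places compound 2 at the limit of > 25000 nM in this assay, at which 1 of the 2 values shown sits. Among the measured compounds shown here, the only measured step that bears on the change is an at least 3.6-fold higher number from compound 1 to compound 2 (0.56 log units; beyond the scatter), with bromo in place of hydrogen on an aromatic carbon. Compound 3 `COc1cc(-c2cccc3nc(-c4ccc(C)cc4)oc23)cc(OC)c1OC` differs by methyl in place of bromo on an aromatic carbon. Given an at least 3.6-fold higher number from compound 1 to compound 2 (0.56 log units; beyond the scatter), compound 3 is expected to return part of the way towards compound 1. In this assay the expected change is an at least 2.0-fold lower number from compound 2 to compound 3 (0.31 log units; beyond the scatter), a modest move towards stronger inhibition. For compound 3 the estimated value is 12000 nM, with an expected range of 5000 nM to 25000 nM.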

Compound 3, half-maximal inhibitory concentration: 1900 nM
The estimate for compound 3 lay 6.3-fold (0.80 log units) above the measured number; the whole stated range lies above it.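

In this assay, a substituent at this place on the ring does not have to weaken the compound, since methyl gives a 3.6-fold lower number from compound 1 to compound 3 (0.55 log units; beyond the scatter), the opposite direction to bromo. Exchanging one group for the other gives an at least 13-fold lower number from compound 2 to compound 3 (1.11 log units; beyond the scatter), so the result at this position depends strongly on which group sits there. That step rests on a limit and not on a number for compound 2: the limit of > 25000 nM in this assay, at which 1 of the 3 values shown sits.

The compounds shown leave open whether a longer chain such as ethyl would improve on methyl. They also leave open how a methoxy group, an amine or a carboxylic acid would fare at this place.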